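This account rests on a few compounds, and the source may have more. Where it says the series, first, only, none or still open, it means among the compounds named here.

Compounds measured so far:
compound 1 `CCN(CCCOc1ccc(C(=O)/C=C/c2ccc(N(C)C)cc2)c(O)c1)Cc1ccccc1` – 82600 nM
compound 2 `CCN(CCCCOc1ccc(C(=O)/C=C/c2ccc(N(C)C)cc2)c(O)c1)Cc1ccccc1OC` – 27500 nM

Both were tested in an assay on isolated protein for inhibition of Amine oxidase [flavin-containing] A (Homo sapiens); a higher number here means a weaker inhibitor, a lower number a stronger inhibitor. Compound 1 gives the highest of the two numbers; compound 2 sits at a lower number, a gap beyond the usual scatter. Compound 3 `CCN(CCCOc1ccc(C(=O)/C=C/c2ccc(N(C)C)cc2)c(O)c1)Cc1ccc(N(C)C)cc1` is not yet measured. It differs from compound 1 in one place: dimethylamino in place of hydrogen on an aromatic carbon. For the measured compounds named here, no pair of measured compounds isolates this change, so there is no measured step to lean on; the expected step is small, likely none beyond the scatter, with a slight lean towards a lower number, as a 1.5-fold lower number from compound 1 to compound 3 (0.18 log units; within the scatter). The estimate for compound 3 is 55000 nM, within 18000 nM to 160000 nM.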

Compound 3, half-maximal inhibitory concentration: 57500 nM
Estimate against measurement, compound 3: 1.0-fold (0.02 log units) below, and the stated range covers the measured number.
By their numbers in this assay, from the lowest: compound 2; then compounds 3 and 1 (each within the scatter of the next).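

Turning benzyl into 4-(dimethylamino)benzyl gives, in this assay, a 1.4-fold lower number from compound 1 to compound 3 (0.16 log units; within the scatter), a step within the usual scatter. So this position, para to a large group, takes dimethylamino, with its 3 heavy atoms, without a change that can be told from repeat-measurement noise. Nothing on hand explains this result. Still open, going by these compounds, is whether a carboxylic acid or a chlorine atom at the same position would shift the number beyond the scatter. A single substituent cannot show how this position responds to other groups.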